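Benzothiazole-bearing hydrazones against maltase-glucoamylase: a methoxy swap

This account rests on a few compounds, and the source may have more. Where it says the series, first, only, none or still open, it means among the compounds named here.

Measured so far:
compound 1, `O=C(N/N=C/c1ccccc1O)c1ccc(-c2nc3ccccc3s2)cc1`: 5550 nM
compound 2, `COC(=O)c1ccc(/C=N/NC(=O)c2ccc(-c3nc4ccccc4s3)cc2)cc1`: "not active" (no number reported)

Compound 1 carries a 2-hydroxyphenyl group and, in an assay on isolated protein for inhibition of Maltase-glucoamylase (Homo sapiens), with a stated time of 15 min (on this read-out higher numbers stand for weaker inhibition and lower numbers for stronger inhibition), compound 1 gives 5550 nM. Going by the values given here, compound 2 is reported as "not active" (no number reported) in this assay, without a number, so compound 1 is the only compound with a stated figure. Compound 3, `COc1cccc(/C=N/NC(=O)c2ccc(-c3nc4ccccc4s3)cc2)c1`, has not been measured. It differs from compound 1 in one place: 3-methoxyphenyl in place of 2-hydroxyphenyl on a carbon with a double bond to nitrogen. With the hydrogen-bond donor gone and compound 2 giving no measurable inhibition, the step is expected to run toward weaker inhibition, beyond the usual scatter, so that compound 3 is estimated at 15000 nM, within a range of 5000 nM to 50000 nM. The step from compound 1 to compound 3 that this estimate implies is a 2.7-fold higher number from compound 1 to compound 3 (0.43 log units; beyond the scatter), and a report of no activity for compound 3 is also quite possible.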

Compound 3, half-maximal inhibitory concentration: 11100 nM
Beside the measured number, compound 3's estimate is 1.4-fold (0.13 log units) above it; low and high end bracket the measured number.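

In this assay, putting 3-methoxyphenyl in place of 2-hydroxyphenyl on a carbon with a double bond to nitrogen comes to a 2.0-fold higher number from compound 1 to compound 3 (0.30 log units; within the scatter), so the data do not separate these two compounds. This shows that a group with no hydrogen-bond donor can stand at this place and still give a number: compound 2 is reported as not active, whereas compound 3 gives 11100 nM. Nothing shown here accounts for this result.

The step changes both the oxygen substituent and its place on the ring, so the compounds shown do not tell these two changes apart. From the compounds shown here alone, it remains open what a 2-methoxyphenyl or 3-hydroxyphenyl group would give here, or how a phenyl ring carrying an amine or a carboxylic acid would read.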